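The source may hold more compounds than are shown below. What is called first, only, known or untested is meant among the compounds shown, and "the series" means these compounds.

Measured compounds:
Compound 1, `CN1CCC(n2cc(S(=O)(=O)c3ccccc3)c3cccnc32)C1`, gives 2.5 nM in an assay on HeLa cells for displacement of a labelled ligand from 5-hydroxytryptamine receptor 6 (Homo sapiens); on this read-out lower numbers stand for stronger inhibition and higher numbers for weaker inhibition.
Compound 2, `CN1CCC(n2cc(S(=O)(=O)c3ccccc3F)c3cccnc32)C1`, gives 5.6 nM in this assay.
Compound 3, `CN1CCC(n2cc(S(=O)(=O)c3ccccc3Cl)c3cccnc32)C1`, gives 2.2 nM in this assay.

Compound 3 gives the lowest of the three numbers. Its nearest neighbour is compound 1, and the step of a 1.1-fold lower number from compound 1 to compound 3 (0.06 log units; within the scatter) lies within the scatter, so the two cannot be ordered. Compound 2 stands furthest off: the step of a 2.5-fold lower number from compound 2 to compound 3 (0.41 log units; beyond the scatter) is modest but beyond the scatter, as is the step of a 2.2-fold higher number from compound 1 to compound 2 (0.35 log units; beyond the scatter).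

Compound 4, `CN1CCC(n2cc(S(=O)(=O)c3ccc(Cl)cc3)c3cccnc32)C1`, keeps every atom of compound 3 but joins them differently: 4-chlorophenyl in place of 2-chlorophenyl on a sulfonyl sulfur. For the measured compounds named here, no measured step moves a chloro group from one position of the phenyl ring to another; the three measured steps only exchange hydrogen, fluoro and chloro at a single position. Going by the values given here, the only evidence that a chlorine on this ring is tolerated is the step of a 1.1-fold lower number from compound 1 to compound 3 (0.06 log units; within the scatter), which was within the scatter. On these data alone, on that slim basis compound 4 is expected to stay close to compound 3, with a wide range because the direction is unknown: the expected step is a 1.6-fold higher number from compound 3 to compound 4 (0.20 log units; within the scatter). The estimate for compound 4 in this assay is 3.5 nM, ranging from 1.2 nM to 12 nM.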

Compound 4, inhibition constant: 4.2 nM
For compound 4 the middle estimate is 1.2-fold (0.08 log units) below the measured one; the measured number falls inside the stated range.
By their numbers in this assay, from the lowest: compounds 3, 1, 4 and 2 (each within the scatter of the next, the first and the last beyond it).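

Moving the chloro group gives the first reading of where on this phenyl ring it sits: in this assay the change shows a 1.9-fold higher number from compound 3 to compound 4 (0.28 log units; within the scatter) and so 4-chlorophenyl and 2-chlorophenyl on the sulfonyl sulfur cannot be ordered. Compound 4 also cannot be ordered against the unsubstituted phenyl, given a 1.7-fold higher number from compound 1 to compound 4 (0.23 log units; within the scatter) or against 2-fluorophenyl, given a 1.3-fold lower number from compound 2 to compound 4 (0.12 log units; within the scatter) and so, among these compounds, the chloro group fits at either printed position without a step beyond the scatter. No evidence is available to explain these numbers.

The compounds shown leave open how a methoxy group, an amine or a carboxylic acid on this phenyl ring would read. They also leave open whether a fluoro group, moved in the same way, would follow the chloro group.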